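A few compounds are considered here, and "the series" means these few. Any claim that something is new, unique, unknown or untested is made for them only; others in the source may bear on it.

Working notes on the series, read in an ADME assay on HFF cells (Homo sapiens) for cytotoxicity, with a stated time of 8 days; a higher number here means that more compound is tolerated, a lower number that less compound is tolerated. Compound 3 `CCCSc1nc(N)nc2c1ncn2/C=C1/CC1(CO)CO` carries propylsulfanyl on the shared core and reads > 300000 nM as a limit, not a number. Compound 1 `CCCCCCCCOc1nc(N)nc2c1ncn2/C=C1/CC1(CO)CO` carries octyloxy there and reads > 300000 nM as a limit too. Compound 2 `CN(C)c1nc(N)nc2c1ncn2/C=C1/CC1(CO)CO` carries dimethylamino there and reads > 300000 nM as a further limit. The whole set is summed up by the limit of > 300000 nM in this assay, at which 3 of the 3 values shown sit, and gives compound 3 no exact starting number.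

The next step leads to compound 4 `Nc1nc(NC2CC2)c2ncn(/C=C3/CC3(CO)CO)c2n1` and puts cyclopropylamino in place of propylsulfanyl on an aromatic carbon. The counted change is cyclopropylamino in place of propylsulfanyl on an aromatic carbon and it keeps the same heavy-atom count.

Three measured exchanges on that aromatic carbon bear on this: a step that the two limits leave unreadable from compound 1 to compound 2 and a step that the two limits leave unreadable from compound 1 to compound 3 and a step that the two limits leave unreadable from compound 2 to compound 3 with no readable size in any of them. From the compounds shown here alone, with octyloxy, dimethylamino and propylsulfanyl all reading at the limit, no step beyond the scatter is expected in this assay for the new group, though cyclopropylamino itself is untested. The expected change is a number no higher from compound 3 to compound 4 (the limit leaves the size open) and a further limit reading is the likeliest outcome. For compound 4 the estimate is 300000 nM with an expected range from 100000 nM to 400000 nM in this series.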

Compound 4, half-maximal cytotoxic concentration: > 300000 nM
Compound 4: no number, only a limit; the forecaster's own chance of this, stated with the estimate: 75%; the middle value sits exactly at the limit.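

Compound 4 reads > 300000 nM, a limit and not a number, so its steps from compound 1, compound 2 and compound 3 cannot be read. The compounds shown leave open whether any group on that aromatic carbon changes the reading in this assay, as the set ends at a single reading: the limit of > 300000 nM in this assay, at which 4 of the 4 values shown sit.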